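Trifluoromethyl for hydroxy on the anilide of compound 2

A few compounds are considered here, and "the series" means these few. Any claim that something is new, unique, unknown or untested is made for them only; others in the source may bear on it.

Compound 2 is `O=C(Nc1ccccc1O)C1c2ccccc2CCN1C(=O)c1ccc(Cl)cc1`. In a functional assay on NUGC-3 cells (Homo sapiens) for inhibition, read by sulforhodamine B assay, with a stated time of 48 h (on this read-out lower numbers stand for stronger inhibition of growth and higher numbers for weaker inhibition of growth), compound 2 gives > 10000 nM, which is a limit of the assay and not a number. Compound 1, `O=C(Nc1cccc(C(F)(F)F)c1)C1NCCc2ccccc21`, also returns only a limit in this assay, > 10000 nM. Compound 3, `O=C(Nc1cccc(O)c1)C1NCCc2ccccc21`, sits at a limit as well, > 10000 nM. Every value shown is of this kind: the limit of > 10000 nM in this assay, at which 3 of the 3 values shown sit. Among the compounds with values here, the one measured step, a step that the two limits leave unreadable from compound 1 to compound 3, therefore has no readable size.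

Compound 4 is `O=C(Nc1ccccc1C(F)(F)F)C1c2ccccc2CCN1C(=O)c1ccc(Cl)cc1`; it differs from compound 2 by trifluoromethyl in place of hydroxy on an aromatic carbon. Within the data shown here, no measured step bears on this change with a readable size; the only comparison of hydroxy against trifluoromethyl on an aromatic carbon, from compound 1 to compound 3, runs between two limits. Both compound 1 with trifluoromethyl on an aromatic carbon and compound 2 with hydroxy on an aromatic carbon returned only limits, and on that basis no step beyond the scatter is expected in this assay. Compound 4 is accordingly expected to give 15000 nM, with a range from 3000 nM to 60000 nM, most probably reported again as a limit. The step this implies, a step that the limit leaves unreadable from compound 2 to compound 4, is expected to stay within scatter.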

Compound 4, concentration for 50% growth inhibition: > 10000 nM
Compound 4 was reported as a limit; the forecaster's own chance of this, stated with the estimate: 80%; the middle value lies beyond the limit too.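

In this assay compound 4 gives > 10000 nM, which is a limit and not a number. Within the data shown here, compound 2 also stands at a limit, so no step from compound 2 to compound 4 can be read: the limit of > 10000 nM in this assay, at which 4 of the 4 values shown sit. The compounds shown leave open how hydroxy and trifluoromethyl on the anilide compare, and which features of this series, if any, give a measurable growth inhibition.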